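Sigma-1 binding: mirror-image pair in the dioxane series

The source may hold more compounds than are shown below. What is called first, only, known or untested is meant among the compounds shown, and "the series" means these compounds.

Measured compounds:
- compound 1 `CC(C)(C)[C@]1(c2ccccc2)OCC[C@H](CCNCc2ccccc2)O1`: 253 nM
- compound 2 `CC[C@@]1(c2ccccc2)OCC[C@@H](CCNCc2ccccc2)O1`: 20 nM

Among the measured compounds shown here, in an assay on brain for displacement of a labelled ligand from Sigma non-opioid intracellular receptor 1 (Cavia porcellus) (on this read-out lower numbers stand for stronger inhibition and higher numbers for weaker inhibition), compound 2 gives 20 nM and stands at the lowest number of the two so far; its nearest neighbour is compound 1, whose number is higher by a margin beyond the usual scatter. Compound 1 carries a tert-butyl group where compound 2 carries an ethyl group, so the two values are not read as a single step.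

Compound 3 `CC[C@]1(c2ccccc2)OCC[C@H](CCNCc2ccccc2)O1` is the next candidate for this assay. Compared with compound 2, (the two compounds have the same atoms and bonds and differ only in configuration as drawn: 2 of 2 stereo elements differ (all stereocentres are inverted: mirror images); a stereocentre at a saturated ring carbon is drawn R in compound 2 and S in compound 3; a stereocentre at a saturated ring carbon is drawn R in compound 2 and S in compound 3). For the measured compounds named here, no pair of measured compounds differs only in configuration, so the size of such a step is not known from the series itself; the two compounds measured so far share neither configuration nor substituent pattern with compound 3 in a way that isolates this change.

The expectation for compound 3 in this assay is a higher number than for compound 2, a step of a 3.0-fold higher number from compound 2 to compound 3 (0.48 log units; beyond the scatter), beyond the scatter but not large. Compound 3 is estimated at 60 nM, with a range from 15 nM to 300 nM.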

Compound 3, inhibition constant: 28 nM
Compound 3: middle estimate off by 2.1-fold (0.33 log units), on the high side; the range from low to high includes it.
By their numbers in this assay, from the lowest: compounds 2 and 3 (each within the scatter of the next); then compound 1.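

In this assay, inverting both stereocentres gives a 1.4-fold higher number from compound 2 to compound 3 (0.15 log units; within the scatter), so the mirror-image pair is not separated by this read-out, and the ethyl series shows no preference for either configuration. The comparison is a clean one, with no change of substituent to confound it: the fact that compounds 2 and 3 differ only in the configuration as drawn. Among the compounds shown here, with the configuration as drawn in compound 3 held, ethyl in place of tert-butyl on a saturated ring carbon gives a 9.0-fold lower number from compound 1 to compound 3 (0.96 log units; beyond the scatter), the first step that isolates this substituent, and it is beyond the scatter, whereas the step in configuration is not.

The compounds shown leave open whether the lack of separation holds only for the ethyl pair, since the mirror image of compound 1 does not appear among them, and a tert-butyl pair could behave differently. They also leave open how the value changes across the range between ethyl and tert-butyl on that ring carbon, for example with methyl, isopropyl or a longer chain such as n-propyl, so two substituents do not yet define a trend.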